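The source may report more compounds than this note shows. Statements on the series, on what has been measured and on what is new or still open speak of the compounds shown alone.

Of the compounds shown here, two built on one shared core have been measured for how well they dissolve. In a physicochemical assay for solubility, in phosphate buffer (a higher number here means a more soluble compound, a lower number a less soluble compound), compound 1, `C[C@@H]1CN([C@H](C)CO)C(=O)c2cccc(NC(=O)c3ccncc3)c2O[C@H]1CN(C)Cc1ccc(Oc2ccccc2)cc1`, gives 1000 nM. Compound 2, `C[C@H]1CN([C@@H](C)CO)C(=O)c2cccc(NC(=O)c3ccncc3)c2O[C@@H]1CN(C)Cc1ccccc1`, is the nearest neighbour in this set. In this assay compound 2 gives 100000 nM, a gap that lies well beyond the usual scatter, so compound 1 stands as the less soluble of the two. Among the compounds with values here, no single-point step links compound 1 and compound 2, so their two values are simply set side by side.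

The piece now turns to compound 3, `C[C@@H]1CN([C@@H](C)CO)C(=O)c2cccc(NC(=O)c3ccncc3)c2O[C@H]1CN(C)Cc1ccc(Oc2ccccc2)cc1`, which has not yet been measured. Its relation to compound 1 is narrow: the two compounds have the same atoms and bonds and differ only in configuration as drawn: 1 of 3 stereo elements differ; a stereocentre at a saturated chain carbon is drawn R in compound 1 and S in compound 3. Nothing is added and nothing removed; only the drawing of one stereocentre changes.

Within the data shown here, with no measured step of this kind to lean on, the expected movement from compound 1 to compound 3 in this assay is small, a 1.2-fold higher number from compound 1 to compound 3 (0.08 log units; within the scatter), and may well sit within the scatter in either direction. The solubility of compound 3 in this assay is therefore estimated at 1200 nM, with a likely range from 300 nM to 5000 nM.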

Compound 3, solubility: 1000 nM
Compound 3: the middle estimate sits 1.2-fold (0.08 log units) above what was measured, within the range that was stated.
By their numbers in this assay, from the lowest: compounds 1 and 3 (each within the scatter of the next); then compound 2.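

Redrawing the stereocentre at a saturated chain carbon from R to S gives, in this assay, no change at the digits printed from compound 1 to compound 3 (within the scatter). Within the data shown here, this is the first direct one-place comparison in the set, and it shows that on the core of compound 1, the configuration at this one carbon can be reversed with no measurable effect on the read-out in this assay. The comparison is a clean one, since no atom or bond is added or removed and only this one centre is redrawn, so nothing else can blur the reading: the fact that compounds 1 and 3 differ only in the configuration as drawn

This single pair speaks for only one of the three stereo elements, so the compounds shown leave open whether redrawing either of the other two would be equally silent in this assay, or whether reversing several at once would matter. They also leave open whether this stereocentre would stay just as silent if the hydroxyl-bearing chain on it were replaced by a longer chain or if a carboxylic acid or an amine stood in place of the hydroxyl.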